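Pyrrolidinyl in Place of Dimethylamino on the Saturated Core

The source may hold more compounds than are shown below. What is called first, only, known or untested is meant among the compounds shown, and "the series" means these compounds.

In a functional assay on CHO cells for antagonist activity at melanin-concentrating hormone receptor 1 (Homo sapiens), read by reporter gene assay (a higher number here means a weaker inhibitor, a lower number a stronger inhibitor), compound 3 `CN(C)CC1CCc2cc(-n3cnc4cc(-c5ccc(Cl)cc5)sc4c3=O)ccc2C1` gives 1.1 nM. Compound 1 `CN(C)CC1=Cc2ccc(-n3cnc4cc(-c5ccc(Cl)cc5)sc4c3=O)cc2CC1` gives 2.7 nM in this assay and compound 2 `O=c1c2sc(-c3ccc(Cl)cc3)cc2ncn1-c1ccc2c(c1)CCC(CN1CCCCC1)=C2` gives 0.75 nM in this assay, so compound 3 sits close to compound 2 and under compound 1. Compound 4 `O=c1c2sc(-c3ccc(Cl)cc3)cc2ncn1-c1ccc2c(c1)CCC(CN1CCCC1)C2` differs from compound 3 by pyrrolidin-1-yl in place of dimethylamino on a saturated chain carbon bound to a saturated ring carbon. Going by the values given here, the only measured change of this kind, an exchange of the same dimethylamino for a cyclic amine on the unsaturated core, is a 3.6-fold lower number from compound 1 to compound 2 (0.56 log units; beyond the scatter), a modest lowering. A lowering of similar or slightly smaller size is expected for compound 4, a 2.2-fold lower number from compound 3 to compound 4 (0.34 log units; beyond the scatter). Compound 4 is therefore estimated at 0.5 nM in this assay, with a range from 0.2 nM to 1.5 nM.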

Compound 4, half-maximal inhibitory concentration: 1.3 nM
The estimate for compound 4 lay 2.6-fold (0.41 log units) below the measured number; low and high end bracket the measured number.
By their numbers in this assay, from the lowest: compounds 2, 3 and 4 (each within the scatter of the next); then compound 1.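

On the saturated core, replacing dimethylamino with pyrrolidin-1-yl gives a 1.2-fold higher number from compound 3 to compound 4 (0.07 log units; within the scatter) in this assay, so at this place the exchange leaves the number within the scatter. Going by these compounds alone, the lowering seen on the unsaturated core, a 3.6-fold lower number from compound 1 to compound 2 (0.56 log units; beyond the scatter), with piperidin-1-yl as the entering group, has no counterpart in this step. No measurement available here accounts for the contrast between the two steps.

Still open, on these data alone, is how piperidin-1-yl or morpholin-4-yl would read on the saturated core. Also open, as far as these compounds go, is whether a longer chain carrying the amine would shift the number.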